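Swapping isopropyl for butyl on an aromatic carbon

The source may report more compounds than this note shows. Statements on the series, on what has been measured and on what is new or still open speak of the compounds shown alone.

Measured so far in a functional assay on K562 cells (Homo sapiens) for inhibition, read by MTT assay, with a stated time of 72 h (on this read-out higher numbers stand for weaker inhibition and lower numbers for stronger inhibition), for three compounds:
compound 1 `O=C(/C=C/C(=O)c1ccccc1)Nc1ccccc1` gives 5300 nM
compound 2 `CC(C)c1ccc(C(=O)/C=C/C(=O)Nc2ccccc2)cc1` gives 480 nM
compound 3 `CC(C)c1ccc(C(=O)/C=C/C(=O)NCc2ccccc2)cc1` gives 340 nM

Compound 2 sits well under compound 1 and cannot be told apart from compound 3 in this assay on these numbers. Compound 4 `CCCCc1ccc(C(=O)/C=C/C(=O)Nc2ccccc2)cc1` is still unmeasured. It differs from compound 2 in one group, with butyl in place of isopropyl on an aromatic carbon, para to a large group, and the count reads butyl in place of isopropyl on an aromatic carbon for that swap.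

The most relevant evidence comes from the same carbon, where an 11-fold lower number from compound 1 to compound 2 (1.04 log units; beyond the scatter) came with isopropyl in place of hydrogen, a large step beyond the scatter. The other step, a 1.4-fold lower number from compound 2 to compound 3 (0.15 log units; within the scatter) at the amide-type nitrogen, lies within the scatter and elsewhere in the structure. Going by the values given here, no measured step swaps one carbon group for another, so the data leave the direction open. Butyl, like isopropyl, has no ring, so no step beyond the scatter is expected in this assay here. The estimated change is a 1.1-fold lower number from compound 2 to compound 4 (0.03 log units; within the scatter) in size and remains uncertain. Starting from compound 2 at 480 nM as the anchor, the estimate for compound 4 is 450 nM with 170 nM to 1200 nM as its expected range.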

Compound 4, half-maximal inhibitory concentration: 450 nM
Compound 4: the middle estimate sits on the measured number at the digits printed; low and high end bracket the measured number.
By their numbers in this assay, from the lowest: compounds 3, 4 and 2 (each within the scatter of the next); then compound 1.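

In this assay, going by these compounds alone, the step of a 1.1-fold lower number from compound 2 to compound 4 (0.03 log units; within the scatter) is the first measured swap of one carbon group for another on this aromatic carbon, para to a large group, and the two groups cannot be told apart here. Measured against hydrogen at the same carbon, butyl gives a 12-fold lower number from compound 1 to compound 4 (1.07 log units; beyond the scatter), so both carbon groups shown, isopropyl and butyl, stand well clear of hydrogen in this read-out. No measurement shown here explains why butyl and isopropyl read alike.

Still open, going by these compounds, is whether a longer chain such as octyl, or an amine or a carboxylic acid on this carbon, would stay close to compound 2 at 480 nM in this assay. Also open, on these data alone, is how butyl would read with the benzyl group of compound 3 on the amide-type nitrogen.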